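Compound 3 to compound 4: a carbonyl-side swap

The source may hold more compounds than are shown below. What is called first, only, known or untested is meant among the compounds shown, and "the series" means these compounds.

In an ADME assay on L6 cells (Rattus norvegicus) for cytotoxicity (a higher number here means a weaker inhibitor, a lower number a stronger inhibitor), compound 1 `O=C(Nc1c(O)cccc1-c1nc2c(C(=O)O)cccc2o1)c1ccccn1` gives 30600 nM and compound 2 `O=C(Nc1c(O)cccc1-c1nc2c(C(=O)O)cccc2o1)c1ncccc1F` gives 204000 nM. Compound 3 `O=C(Nc1c(O)cccc1-c1nc2c(C(=O)O)cccc2o1)c1ccccc1O` gives 85100 nM, the second highest of the three numbers. Compound 4 `O=C(Nc1c(O)cccc1-c1nc2c(C(=O)O)cccc2o1)c1cc2ccccc2[nH]1` has 1H-indol-2-yl in place of 2-hydroxyphenyl on a carbonyl carbon. Two measured changes at this place bear on it, a 2.8-fold higher number from compound 1 to compound 3 (0.44 log units; beyond the scatter) and a 2.4-fold lower number from compound 2 to compound 3 (0.38 log units; beyond the scatter), and both are modest. Within the data shown here, no measured compound carries 1H-indol-2-yl, so the direction is tentative. A modest move toward the lower end of the series is expected in this assay, and the estimated step is a 2.2-fold lower number from compound 3 to compound 4 (0.35 log units; beyond the scatter). The estimate for compound 4 is 38000 nM, with an expected range of 12000 nM to 120000 nM.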

Compound 4, half-maximal inhibitory concentration: 212000 nM
Beside the measured number, compound 4's estimate is 5.6-fold (0.75 log units) below it; measured number outside the range, above it.
By their numbers in this assay, from the lowest: compound 1; then compound 3; then compounds 2 and 4 (each within the scatter of the next).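

In this assay the 1H-indol-2-yl group on the carbonyl carbon does not bring the number down: the series shows a 2.5-fold higher number from compound 3 to compound 4 (0.40 log units; beyond the scatter) and a 6.9-fold higher number from compound 1 to compound 4 (0.84 log units; beyond the scatter) and pyridin-2-yl keeps the lowest number of the four. With a 1.0-fold higher number from compound 2 to compound 4 (0.02 log units; within the scatter) two quite different groups, 3-fluoropyridin-2-yl and 1H-indol-2-yl, now sit together at the high end of the series. No evidence here accounts for these steps.

Still open, from the compounds shown here alone, is whether an amine such as piperidin-4-yl or a plain alkyl chain on this carbonyl carbon would stay near compound 1.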